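A few compounds are considered here, and "the series" means these few. Any claim that something is new, unique, unknown or untested is made for them only; others in the source may bear on it.

Compound 1, `COc1ccc(Nc2c(NCCCCCC(=O)NO)c(=O)c2=O)cc1`, is measured in a physicochemical assay for solubility, read by HPLC, in phosphate buffer, with a stated time of 24 h, at pH 7.4, tested at 100 uM (on this read-out lower numbers stand for lower solubility and higher numbers for higher solubility), and gives 3300000 nM. Compound 2, `COc1ccc(Nc2c(NC(C)CCCCC(=O)NO)c(=O)c2=O)cc1`, differs from it by methyl in place of hydrogen on a saturated chain carbon bound to a nitrogen on an aromatic ring and a saturated chain carbon, and in this assay compound 2 gives 85000000 nM, so the pair shows a 26-fold higher number from compound 1 to compound 2 (1.41 log units; beyond the scatter). Compound 3, `CCC(CCCCC(=O)NO)Nc1c(Nc2ccc(C(F)(F)F)cc2)c(=O)c1=O`, has a different core; the difference between the two cores is not broken down here. In this assay compound 3 gives 6600000 nM, which stands within the scatter of the number for compound 1 and well below the number for compound 2.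

Compound 4, `CC(C)C(CCCCC(=O)NO)Nc1c(Nc2ccc(C(F)(F)F)cc2)c(=O)c1=O`, has not yet been measured. It differs from compound 3 by methyl in place of hydrogen on a saturated chain carbon bound to two saturated chain carbons. Among the measured compounds shown here, this is the same kind of change as the one from compound 1 to compound 2, but the place is not the same: there the carbon was bound to a nitrogen on an aromatic ring and a saturated chain carbon, here it is bound to two saturated chain carbons. Because the earlier step was a 26-fold higher number from compound 1 to compound 2 (1.41 log units; beyond the scatter), an upward step is expected here too, though a smaller one, estimated as a 1.5-fold higher number from compound 3 to compound 4 (0.18 log units; within the scatter), since the place differs. Compound 4 is therefore expected to give about 10000000 nM, most likely between 3000000 nM and 40000000 nM.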

Compound 4, solubility: 5300000 nM
Compound 4: middle estimate off by 1.9-fold (0.28 log units), on the high side; measured number inside the range.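

In this assay the change from ethyl to isopropyl on the core of compound 3 gives a 1.2-fold lower number from compound 3 to compound 4 (0.10 log units; within the scatter) and so leaves the two compounds indistinguishable, while methyl in place of hydrogen on the core of compound 1 gave a 26-fold higher number from compound 1 to compound 2 (1.41 log units; beyond the scatter) in that same read-out. The large step therefore did not carry over in this one case, but the change also sits at a different place in each pair, so the two pairs cannot separate the effect of the core from that of the place and give no general rule for moving the change between cores. Nothing measured here explains why the two steps differ.

The compounds shown leave open how an amine or a longer chain in place of the isopropyl of compound 4 would read in this assay on this core. They also leave open whether ethyl to isopropyl would read the same on the core of compound 1.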